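Methyl to Cyano on Two Different Cores

The compounds below may be only part of what the source reports. "The series", "measured", "known", "first", "only" and "open" are said of these compounds alone.

Measured in a functional assay on HEK293 cells for agonist activity at D(4) dopamine receptor (Homo sapiens), read by FLIPR; on this read-out lower numbers stand for smaller maximal responses and higher numbers for larger maximal responses:
Compound 1 `Cc1cccc(C(=O)NCN2CCC(c3cccc[n+]3[O-])CC2)c1` gives 77%
Compound 2 `N#Cc1cccc(C(=O)NCN2CCC(c3cccc[n+]3[O-])CC2)c1` gives 69%
Compound 3 `Cc1cccc(NC(=O)CN2CCC(c3ccccc3C)CC2)c1` gives 43%

Compound 1 and compound 2 share one core; the change from the first to the second is cyano in place of methyl on an aromatic carbon and the step it made is a number 8 percentage points lower from compound 1 to compound 2 (within the scatter). Compound 3 rests on a different core; the difference between the two cores is not broken down here. Compound 4 `Cc1cccc(NC(=O)CN2CCC(c3ccccc3C#N)CC2)c1` is not yet measured and differs from compound 3 by cyano in place of methyl on an aromatic carbon. This is the same kind of change as before, not the same: around the place, the earlier change sits meta to a large group, the new one ortho to a large group. For the measured compounds named here, since the only measured step of this kind is small, the step from compound 3 to compound 4 is expected to be a number 6 percentage points lower from compound 3 to compound 4 (within the scatter) in this assay, because a number 8 percentage points lower from compound 1 to compound 2 (within the scatter) was within the scatter. Compound 4 is therefore estimated at 37%, expected between 20% and 55%.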

Compound 4, largest response reached (reported as efficacy), in percent of the reference or control that the assay uses: 71%
The estimate for compound 4 lay 34 percentage points below the measured number, and the stated range ends below it.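

In this assay, replacing methyl with cyano did not behave the same way on the two cores, and the new step is a number 28 percentage points higher from compound 3 to compound 4 (beyond the scatter). The two steps do not match: the same change on two cores in this assay, a number 8 percentage points lower (within the scatter) from compound 1 to compound 2 and a number 28 percentage points higher (beyond the scatter) from compound 3 to compound 4, 36 percentage points apart, beyond the scatter of two such steps. This shows that the result of this change on one core could not be carried over to the other, but it does not show why, as the cores differ, the place of the change differs, and a single pair on each core cannot separate these two differences.

From the compounds shown here alone, it remains open whether a chlorine atom or a methoxy group in the same place would also raise the response on the core of compound 3. A third core might follow either pattern.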